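This account rests on a few compounds, and the source may have more. Where it says the series, first, only, none or still open, it means among the compounds named here.

Compound 1 `C[C@H](NC(=O)C(c1cccnc1)N(C(=O)c1c[nH]cn1)c1ccc(-c2ccccc2)cc1)c1ccccc1` is followed here to compound 4 `C[C@H](NC(=O)C(c1cnccn1)N(C(=O)c1c[nH]cn1)c1ccc(-c2ccccc2)cc1)c1ccccc1`. In a toxicity assay on Vero C1008 cells (Chlorocebus sabaeus) for cytotoxicity, read by neutral red uptake, with a stated time of 5 days (a higher number here means that more compound is tolerated, a lower number that less compound is tolerated), compound 1 gives 129000 nM, the highest of the two plain numbers measured. Compound 3 `C[C@H](NC(=O)C(c1cccnc1)N(C(=O)c1cnco1)c1ccc(-c2ccccc2)cc1)c1ccccc1` gives 67100 nM, and the step of a 1.9-fold lower number from compound 1 to compound 3 (0.28 log units; within the scatter) stays within the scatter. Compound 2 `C[C@H](NC(=O)C(c1cccnc1)N(C(=O)c1ccno1)c1ccc(-c2ccccc2)cc1)c1ccccc1` reaches only a limit of the assay, > 200000 nM, as noted in the limit of > 200000 nM in this assay, at which 1 of the 3 values shown sits. The change to compound 4 is pyrazin-2-yl in place of pyridin-3-yl on a saturated chain carbon bound to an amide-type nitrogen and a carbonyl carbon. Every measured step, including an at least 1.5-fold higher number from compound 1 to compound 2 (0.19 log units; that floor lies within the scatter) and an at least 2.9-fold lower number from compound 2 to compound 3 (0.47 log units; beyond the scatter), altered the group on the carbonyl carbon instead, so none of them speaks to this new place, and no step beyond the scatter is expected in this assay. The step of a 1.0-fold higher number from compound 1 to compound 4 (0.00 log units; within the scatter) is the resulting estimate. Compound 4 is expected to give 130000 nM, between 60000 nM and 250000 nM.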

Compound 4, half-maximal cytotoxic concentration: 148000 nM
Compound 4: the middle estimate sits 1.1-fold (0.06 log units) below what was measured; low and high end bracket the measured number.
By their numbers in this assay, from the lowest: compounds 3, 1 and 4 (each within the scatter of the next, the first and the last beyond it). At a limit, above all of these: compound 2.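

Within the data shown here, this is the first look at the saturated chain carbon bound to an amide-type nitrogen and a carbonyl carbon: in this assay, pyrazin-2-yl in place of pyridin-3-yl gives a 1.1-fold higher number from compound 1 to compound 4 (0.06 log units; within the scatter). At this place, then, one six-membered aromatic ring can replace the other without a step beyond the scatter. Nothing measured here bears on why this step is so small. Going by these compounds, it remains open how a non-aromatic group, such as an amine or a carboxylic acid, would fare at this place. Also open, on these data alone, is whether pyrazin-2-yl gives the same picture alongside 1,2-oxazol-5-yl or 1,3-oxazol-5-yl on the carbonyl carbon.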